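The source may report more compounds than this note shows. Statements on the series, on what has been measured and on what is new or still open speak of the compounds shown alone.

In an ADME assay on CHO cells (Cricetulus griseus) for cytotoxicity, read by LDH release (on this read-out higher numbers stand for weaker inhibition and lower numbers for stronger inhibition), compound 1 (`CCCC(NC(=O)C(C)Oc1ccc(Cl)cc1Cl)c1ccc(F)cc1`) gives > 100000 nM, which is a limit of the assay and not a number. Compound 2 (`CC(Oc1ccc(Cl)cc1Cl)C(=O)NC(c1ccc(F)cc1)C1CC1`) also gives only a limit, > 100000 nM. The data show no more than the limit of > 100000 nM in this assay, at which 2 of the 2 values shown sit. Compound 3 (`CC(Oc1ccc(Cl)cc1Cl)C(=O)NC(CO)c1ccc(F)cc1`) differs from compound 2 by hydroxymethyl in place of cyclopropyl on a saturated chain carbon bound to an amide-type nitrogen and an aromatic carbon, with hydroxymethyl in place of cyclopropyl. Going by the values given here, the only measured step, a step that the two limits leave unreadable from compound 1 to compound 2, has no readable size, so no step beyond the scatter is expected in this assay. Compound 3 is estimated at 100000 nM, with an expected range from 50000 nM to 200000 nM. The expected step is a number no higher from compound 2 to compound 3 (the limit leaves the size open).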

Compound 3, half-maximal inhibitory concentration: 18000 nM
The estimate for compound 3 lay 5.6-fold (0.74 log units) above the measured number; the whole stated range lies above it.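

In this assay, this position proves able to move the read-out: hydroxymethyl in place of cyclopropyl gives an at least 5.5-fold lower number from compound 2 to compound 3 (0.74 log units; beyond the scatter). Measured against the propyl chain, hydroxy in place of ethyl gives an at least 5.5-fold lower number from compound 1 to compound 3 (0.74 log units; beyond the scatter). Both steps are open-ended in size because each starts from a limit of the assay, not a number: the limit of > 100000 nM in this assay, at which 2 of the 3 values shown sit.

The compounds shown leave open whether the hydroxy group itself drives the lower number or any small replacement of the carbon groups would do the same. A methoxymethyl or aminomethyl group at this position could separate these two readings.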